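Putting a Hydroxyl Back Where Halogens Stood

The compounds below may be only part of what the source reports. "The series", "measured", "known", "first", "only" and "open" are said of these compounds alone.

Compound 1 `CN(C)CCn1cnnc1-c1cc(Oc2ccc(NC(=O)N/N=C/c3cccc(O)c3)cc2F)ccn1`: in a functional assay on U-87MG ATCC cells (Homo sapiens) for cytotoxicity, read by MTT assay, with a stated time of 72 h (a higher number here means a weaker inhibitor, a lower number a stronger inhibitor), compound 1 gives > 100000 nM, which is a limit of the assay and not a number.
Compound 2 `CN(C)CCn1cnnc1-c1cc(Oc2ccc(NC(=O)N/N=C/c3ccc(F)cc3Cl)cc2F)ccn1`: in this assay compound 2 gives 1210 nM.
Compound 3 `CN(C)CCn1cnnc1-c1cc(Oc2ccc(NC(=O)N/N=C/c3cccc(Cl)c3Cl)cc2F)ccn1`: in this assay compound 3 gives 13200 nM.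

Compound 2 has the lowest of the two measured numbers; compound 3 stands an 11-fold higher number from compound 2 to compound 3 (1.04 log units; beyond the scatter) away. All three share one core and differ only in the aryl group on the carbon with a double bond to nitrogen. The unmeasured compound 4 `CN(C)CCn1cnnc1-c1cc(Oc2ccc(NC(=O)N/N=C/c3ccc(O)c(F)c3)cc2F)ccn1` changes that same place: 3-fluoro-4-hydroxyphenyl in place of 2-chloro-4-fluorophenyl on a carbon with a double bond to nitrogen. The step that bears most on this is an at least 82-fold lower number from compound 1 to compound 2 (1.91 log units; beyond the scatter), where a hydroxyl-bearing phenyl gave way to a halogenated phenyl. Compound 4 brings a hydroxyl back while keeping one fluorine, so that step is expected to run largely in reverse, with a large rise in the number. The expected step is a 33-fold higher number from compound 2 to compound 4 (1.52 log units; beyond the scatter). Since compound 1 sits at the assay limit (the limit of > 100000 nM in this assay, at which 1 of the 3 values shown sits), compound 4 may well return only a limit too. Compound 4 is estimated at 40000 nM, within 8000 nM to 200000 nM.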

Compound 4, half-maximal inhibitory concentration: > 100000 nM
Compound 4 gave a limit, no number (the forecaster's own chance of this, stated with the estimate: 40%); at least 2.5-fold (0.39 log units) between middle value and limit.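

In this assay, the change to 3-fluoro-4-hydroxyphenyl gives an at least 82-fold higher number from compound 2 to compound 4 (1.91 log units; beyond the scatter) and an at least 7.5-fold higher number from compound 3 to compound 4 (0.87 log units; beyond the scatter). Among the compounds shown here, a fluorine on the phenyl ring therefore does not by itself keep a measurable number once a hydroxyl is also present, a case the earlier compounds did not cover. Among these four compounds, the two carrying a hydroxyl give limits and the two carrying only halogens give numbers, and none goes against this pattern. The step from compound 1 to compound 4 cannot be read, as each gives a limit and not a number: the limit of > 100000 nM in this assay, at which 2 of the 4 values shown sit.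

On these data alone, it remains open whether this loss follows the hydroxyl itself or would also appear with a methoxy group or an amine on the same ring. As far as these compounds go, how a phenyl ring carrying fluorine alone would behave at this position also stays unknown.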